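From phenyl to 4-nitrophenyl in a small series

This account rests on a few compounds, and the source may have more. Where it says the series, first, only, none or still open, it means among the compounds named here.

Of the compounds shown here, three with a similar core have numbers so far in a functional assay on A549 cells (Homo sapiens) for antiproliferative activity, read by MTT assay, with a stated time of 48 h (a higher number here means a weaker inhibitor, a lower number a stronger inhibitor), and they sit close together. Compound 1 (`Cc1ccc2nc(NC(c3cn(-c4ccccc4)nc3-c3cccc(Cl)c3)c3c(O)ccc4ccccc34)sc2c1`) gives 45400 nM there, compound 2 (`Cc1ccc(-c2nn(-c3ccccc3)cc2C(Nc2nc3cc(C)c(C)cc3s2)c2c(O)ccc3ccccc23)cc1`) gives 31200 nM there, and compound 3 (`Oc1ccc2ccccc2c1C(Nc1nc2ccccc2s1)c1cn(-c2ccccc2)nc1-c1ccccc1`) gives 36200 nM there. Compound 3 stands in the middle of this cluster, with the values of compound 1 and compound 2 both within the usual scatter of its own, so the three cannot be ranked. Among the measured compounds shown here, they differ from one another in more than one place, and no measured pair isolates a single change.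

Compound 4 (`O=[N+]([O-])c1ccc(-c2nn(-c3ccccc3)cc2C(Nc2nc3ccccc3s2)c2c(O)ccc3ccccc23)cc1`) is compound 3 with one alteration: nitro in place of hydrogen on an aromatic carbon turns phenyl into 4-nitrophenyl, with nitro in place of hydrogen on an aromatic carbon, para to a large group. For the measured compounds named here, the data hold no direct precedent for this change, so the expectation in this assay is only a small step toward a lower number, not beyond the scatter. It rests on compound 3 at 36200 nM and on the tight cluster around it. The estimated step of a 1.3-fold lower number from compound 3 to compound 4 (0.11 log units; within the scatter) is accordingly a modest one. Compound 4 is estimated at 28000 nM within an expected range from 12000 nM to 60000 nM in this assay by this reckoning.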

Compound 4, half-maximal inhibitory concentration: 41300 nM
For compound 4 the middle estimate is 1.5-fold (0.17 log units) below the measured one; the measured number falls inside the stated range.
By their numbers in this assay, from the lowest: compounds 2, 3, 4 and 1 (each within the scatter of the next).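

Among the compounds shown here, compound 3 and compound 4 form the first measured pair that differs in only one place, so the effect of a single change can now be read. In this assay nitro in place of hydrogen on an aromatic carbon, para to a large group, gives a 1.1-fold higher number from compound 3 to compound 4 (0.06 log units; within the scatter), so turning phenyl into 4-nitrophenyl leaves no mark that can be told from the scatter. At this position and in this assay, the change adds three heavy atoms and two hydrogen-bond acceptors without moving compound 4 out of the tight cluster, and nothing among the data given explains this outcome.

For the compounds shown here, the single pair covers only one group at one position, so whether an amine or a carboxylic acid on the same aromatic carbon would give a step beyond the scatter remains open. Going by these compounds, it is also open whether nitro would give the same result on another aromatic ring of the shared core, or alongside the other differences carried by compound 1 and compound 2.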